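The source may hold more compounds than are shown below. What is called first, only, known or untested is meant among the compounds shown, and "the series" means these compounds.

Compound 1, `CC1=CC[C@H](C(C)(C)NC(=S)N/N=C/c2ccccc2)CC1`, gives 84400 nM in a functional assay on MCF7 cells (Homo sapiens) for inhibition, read by sulforhodamine B assay, with a stated time of 48 h; on this read-out higher numbers stand for weaker inhibition of growth and lower numbers for stronger inhibition of growth.
Compound 2, `CC1=CC[C@H](C(C)(C)NC(=S)N/N=C/c2ccc(N(C)C)cc2)CC1`, gives only a limit, > 100000 nM.

Compound 2 thus stands at the limit of this assay, the line (the limit of > 100000 nM in this assay, at which 1 of the 2 values shown sits), and no number is known for it. Within the data shown here, the only measured step, an at least 1.1-fold higher number from compound 1 to compound 2 (0.07 log units; that floor lies within the scatter), is bounded by that limit and its floor lies within the scatter, so it shows no clear effect of the dimethylamino group. Compound 3, `CC1=CC[C@H](C(C)(C)NC(=S)N/N=C/c2ccc(F)cc2)CC1`, differs from compound 2 by fluoro in place of dimethylamino on an aromatic carbon. The measured step bears on this change only loosely, since one end of it is a limit; compound 1 carries hydrogen on the aromatic carbon and offers the nearest point of reference. Compound 3 is therefore expected to sit near the number of compound 1, 84400 nM. For compound 3 the expected step is an at least 1.1-fold lower number from compound 2 to compound 3 (0.04 log units; that floor lies within the scatter), within the scatter. The estimate for compound 3 is 90000 nM, between 40000 nM and 200000 nM.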

Compound 3, concentration for total growth inhibition: > 100000 nM
Compound 3 ended at the assay's limit; the forecaster's own chance of this, stated with the estimate: 45%; at least 1.1-fold (0.04 log units) between middle value and limit.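

With fluoro in place of hydrogen on this aromatic carbon, para to a large group, this assay gives an at least 1.1-fold higher number from compound 1 to compound 3 (0.07 log units; that floor lies within the scatter), so a substituent of a single heavy atom shows no clear effect here, just as dimethylamino showed none. The change from dimethylamino to fluoro cannot be read, and neither group has a number in this assay. Compound 3, like compound 2, gives only a limit, and the series now sits largely at that line: the limit of > 100000 nM in this assay, at which 2 of the 3 values shown sit.

Whether any group on this aromatic carbon can lower the number stays open, and the compounds shown say nothing about a methoxy group or a carboxylic acid there. Also open, from the compounds shown here alone, is what fluoro or dimethylamino would give elsewhere on the six-membered aromatic ring.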